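A few compounds are considered here, and "the series" means these few. Any claim that something is new, unique, unknown or untested is made for them only; others in the source may bear on it.

Three compounds that share one core, each tested in an ADME assay on HEK-293T cells (Homo sapiens) for cytotoxicity, read by CCK-8 assay, with a stated time of 48 h (on this read-out lower numbers stand for stronger inhibition and higher numbers for weaker inhibition), set the scene. Compound 1 `O=C(NCCNS(=O)(=O)c1ccc(-c2ccccc2Oc2ccc(O)c(O)c2)s1)Nc1cc(Cl)cc(Cl)c1` gives 12400 nM. Compound 2 `Nc1ccc(Oc2ccccc2-c2ccc(S(=O)(=O)NCCNC(=O)Nc3ccc(Cl)cc3)s2)cc1` returns only a limit of the assay, > 20000 nM. Compound 3 `O=C(NCCNS(=O)(=O)c1ccc(-c2ccccc2Oc2ccc([N+](=O)[O-])c([N+](=O)[O-])c2)s1)Nc1cc(C(F)(F)F)cc(C(F)(F)F)c1` likewise returns only a limit of the assay, > 50000 nM. On the numbers shown, compound 3 therefore has no value of its own, only a boundary, and it is one of two such boundaries: the limit of > 20000 nM in this assay, at which 1 of the 3 values shown sits, and (the limit of > 50000 nM in this assay, at which 1 of the 3 values shown sits).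

Compound 4 `Nc1ccc(Oc2ccccc2-c2ccc(S(=O)(=O)NCCNC(=O)Nc3cc(C(F)(F)F)cc(C(F)(F)F)c3)s2)cc1` has not yet been measured. It differs from compound 3 by 4-aminophenyl in place of 3,4-dinitrophenyl on an oxygen on an aromatic ring. The 4-aminophenyl group that enters is the same group carried by compound 2, which also returned only a limit. No step beyond the scatter is expected in this assay, and the estimated step is an at least 1.2-fold lower number from compound 3 to compound 4 (0.09 log units; that floor lies within the scatter). Compound 4 is expected to give 40000 nM, within a range of 15000 nM to 100000 nM, and most probably the assay will again report only a limit rather than a number.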

Compound 4, half-maximal inhibitory concentration: > 20000 nM
Compound 4: no number, only a limit; the forecaster's own chance of this, stated with the estimate: 70%; the middle value does not contradict the limit.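

Compound 3 and compound 4 both return only limits of the assay in this assay, so no step can be read between them. The compounds shown leave open how far 4-aminophenyl in place of 3,4-dinitrophenyl actually shifts the read-out, as neither compound has a number of its own.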